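The source may report more compounds than this note shows. Statements on the series, on what has been measured and on what is new or still open speak of the compounds shown alone.

Measured compounds in a functional assay on MCF7 cells (Homo sapiens) for antiproliferative activity; a higher number here means a weaker inhibitor, a lower number a stronger inhibitor:
- compound 1 `COC(CN(c1ccccc1CO)S(=O)(=O)c1ccc([N+](=O)[O-])cc1)n1ccc(=O)[nH]c1=O` gives 45800 nM
- compound 2 `O=[N+]([O-])c1ccccc1S(=O)(=O)N1CC(n2cnc3ncnc(Sc4ccccc4)c32)OCc2ccccc21` gives 2590 nM
- compound 3 `O=[N+]([O-])c1ccc(S(=O)(=O)N2CC(n3cnc4ncnc(Sc5ccccc5)c43)OCc3ccccc32)cc1` gives 860 nM

Compound 4 `COC(CN(c1ccccc1CO)S(=O)(=O)c1ccccc1[N+](=O)[O-])n1ccc(=O)[nH]c1=O` has not yet been measured. It differs from compound 1 by 2-nitrophenyl in place of 4-nitrophenyl on a sulfonyl sulfur. The same kind of change, (2-nitrophenyl in place of 4-nitrophenyl on a sulfonyl sulfur), links compound 3 to compound 2, though there the sulfonamide nitrogen sits in a ring. That earlier change produced a 3.0-fold higher number from compound 3 to compound 2 (0.48 log units; beyond the scatter). The difference between the core of compound 1 and the core of compound 3 is not broken down here, and compound 1 sits far weaker than either.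

Among the measured compounds shown here, for compound 4 a similar weakening is expected, a 2.2-fold higher number from compound 1 to compound 4 (0.34 log units; beyond the scatter), resting on that single earlier step; with only one example and a different core, this rests on thin ground. Compound 4 is therefore estimated at 100000 nM, in the range 35000 nM to 300000 nM, with a real chance that this assay reports only a limit.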

Compound 4, half-maximal inhibitory concentration: 64800 nM
Estimate against measurement, compound 4: 1.5-fold (0.19 log units) above, and the stated range covers the measured number.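

In this assay, 2-nitrophenyl in place of 4-nitrophenyl on a sulfonyl sulfur gives a 1.4-fold higher number from compound 1 to compound 4 (0.15 log units; within the scatter). Set beside the same change on the other core, the two steps cannot be told apart: the same change on two cores in this assay, a 3.0-fold higher number (0.48 log units; beyond the scatter) from compound 3 to compound 2 and a 1.4-fold higher number (0.15 log units; within the scatter) from compound 1 to compound 4, 2.1-fold (0.33 log units) apart, within the scatter of two such steps. This shows that the change carries from one core to the other without a detectable difference in size, but two pairs do not establish a fixed step, and the new step alone cannot be told from no change at all.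

The compounds shown leave open what an amine or a carboxylic acid in place of the nitro group would do on either core. They also leave open whether the two cores would still respond alike to such a group.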